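This account rests on a few compounds, and the source may have more. Where it says the series, first, only, none or still open, it means among the compounds named here.

Measured compounds:
- compound 1 `NCc1csc(NC(=O)c2ccn[nH]2)n1` gives 0.1 in a physicochemical assay for lipophilicity, read by HPLC, at pH 7.4; on this read-out higher numbers stand for higher lipophilicity and lower numbers for lower lipophilicity
- compound 2 `CC(C)(C)c1cc(C(=O)Nc2ccccn2)n(Cc2ccccc2)n1` gives 4.5 in this assay
- compound 3 `CC(=O)NCc1csc(NC(=O)c2cc(C(C)(C)C)nn2Cc2ccccc2)n1` gives 3.3 in this assay

Of these three, compound 2 stands highest in this assay. Its nearest neighbour is compound 3, whose number is lower by a margin beyond the usual scatter, and furthest away is compound 1, lower by a much larger margin. Compound 4 `CC(C)(C)c1cc(C(=O)Nc2cccc(CN)c2)n(Cc2ccccc2)n1` has not yet been measured in this assay. It is derived from compound 2 by one change: 3-(aminomethyl)phenyl in place of pyridin-2-yl on an amide-type nitrogen The group that leaves carries no hydrogen-bond donor, while the group that enters carries one.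

Within the data shown here, no step between measured compounds covers this exact change, so the expectation rests on the wider picture. Among the measured compounds shown here, compound 1, the only measured compound that carries an aminomethyl group, gives the lowest number of the three, 0.1 in this assay. From compound 2 to compound 4 a downward step well beyond the scatter is therefore expected, of about a number 2.20 log units lower from compound 2 to compound 4 (beyond the scatter). Compound 4 is estimated at 2.3, within a range from 1.5 to 3.2.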

Compound 4, distribution coefficient: 2.9
Compound 4: the middle estimate sits 0.60 log units below what was measured; low and high end bracket the measured number.
By their numbers in this assay, from the lowest: compound 1; then compound 4; then compound 3; then compound 2.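

Among these compounds, the first one-place step at this amide-type nitrogen shows that, in this assay, exchanging pyridin-2-yl for 3-(aminomethyl)phenyl gives a number 1.60 log units lower from compound 2 to compound 4 (beyond the scatter). The number therefore falls even though the entering group is the larger one, and the change brings in a hydrogen-bond donor and replaces a ring with one hetero atom by a ring of carbon only. No measurement here accounts for the size or direction of this step.

The compounds shown leave open how the step divides between the exchange of the ring and the aminomethyl group, a division that a plain phenyl on this nitrogen could help to settle. From the compounds shown here alone, how a 3-(hydroxymethyl)phenyl or a 3-(2-aminoethyl)phenyl group would read in this assay also remains open.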